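The source may hold more compounds than are shown below. What is called first, only, known or untested is meant among the compounds shown, and "the series" means these compounds.

Working notes on the series. Compound 2 `COc1cc(OC)c(OC)cc1/C=C/C(=O)NCCNc1ccnc2cc(Cl)ccc12` and compound 1 `COc1ccc(/C=C/C(=O)NCCNc2ccnc3cc(Cl)ccc23)cc1OC` share one core. In an ADME assay on Vero cells (Chlorocebus sabaeus) for cytotoxicity, read by MTT assay, with a stated time of 72 h (on this read-out higher numbers stand for lower toxicity in this test and lower numbers for higher toxicity in this test), compound 2 gives 16100 nM, and compound 1 gives 5600 nM; the step is a 2.9-fold lower number from compound 2 to compound 1 (0.46 log units; beyond the scatter), the change being (hydrogen in place of methoxy on an aromatic carbon). Compound 3 `COc1cc(OC)c(OC)cc1/C=C/C(=O)c1ccccc1OCC(=O)NCCNc1ccnc2cc(Cl)ccc12` rests on a different core; the difference between the two cores is not broken down here. In this assay compound 3 gives 12300 nM. Compound 4 `COc1ccc(/C=C/C(=O)c2ccccc2OCC(=O)NCCNc2ccnc3cc(Cl)ccc23)cc1OC` stands to compound 3 as compound 1 stands to compound 2, the change being (hydrogen in place of methoxy on an aromatic carbon); the surroundings of the place match word for word, so it is the same change. For the measured compounds named here, the only precedent is a 2.9-fold lower number from compound 2 to compound 1 (0.46 log units; beyond the scatter), a modest step beyond the scatter. Resting on that single precedent, a step of like size is expected, a 2.7-fold lower number from compound 3 to compound 4 (0.44 log units; beyond the scatter). Compound 4 is accordingly estimated at 4500 nM, with a range from 2300 nM to 9000 nM.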

Compound 4, half-maximal cytotoxic concentration: 5310 nM
For compound 4 the middle estimate is 1.2-fold (0.07 log units) below the measured one; the measured number falls inside the stated range.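

In this assay the change from 2,4,5-trimethoxyphenyl to 3,4-dimethoxyphenyl gives a 2.3-fold lower number from compound 3 to compound 4 (0.36 log units; beyond the scatter), so in this series it carries from one core to the other in both direction and size: the same change on two cores in this assay, a 2.9-fold lower number (0.46 log units; beyond the scatter) from compound 2 to compound 1 and a 2.3-fold lower number (0.36 log units; beyond the scatter) from compound 3 to compound 4, 1.2-fold (0.09 log units) apart, within the scatter of two such steps. This agreement rests on two matched pairs, one on each core, and supports carrying the change only between these two cores and only in this assay. It does not show that the step would hold on any further core, and it does not explain why the number falls.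

Still open, from the compounds shown here alone, is how this assay responds to other groups at the same place, such as a hydroxy group, a chlorine or an amine. Also open, going by these compounds, is whether the step persists on a core bearing a carboxylic acid.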